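The source may report more compounds than this note shows. Statements on the series, on what has been measured and on what is new or still open speak of the compounds shown alone.

In a functional assay on HeLa cells (Homo sapiens) for inhibition (on this read-out lower numbers stand for stronger inhibition and higher numbers for weaker inhibition), compound 1 `Cc1cn(/C=C/C=O)c(=O)[nH]c1=O` gives 100000 nM, and compound 2 `O=C/C=C/n1cc(F)c(=O)[nH]c1=O` gives 90000 nM. Both numbers are very high on this read-out, which means weak inhibition, and compound 2 cannot be told apart from compound 1. The next compound to be tested is compound 3 `O=C/C=C/n1cc(CO)c(=O)[nH]c1=O`. It keeps the shared core and alters one group: hydroxymethyl in place of fluoro on an aromatic carbon. In words, this is hydroxymethyl in place of fluoro on an aromatic carbon.

Going by the values given here, only one measured step bears on this change, and it concerns the same aromatic carbon: a 1.1-fold lower number from compound 1 to compound 2 (0.05 log units; within the scatter), with fluoro in place of methyl. That single step stayed within the scatter. Among the compounds with values here, it offers limited guidance, however, since no measured compound carries hydroxymethyl yet. In this assay, the expected result is therefore a 1.1-fold lower number from compound 2 to compound 3 (0.05 log units; within the scatter), which means no real change is expected beyond the scatter. For compound 3 the estimated value is 80000 nM, with an expected range from 30000 nM to 200000 nM.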

Compound 3, half-maximal inhibitory concentration: > 100000 nM
Compound 3 ended at the assay's limit; the forecaster's own chance of this, stated with the estimate: 25%; middle value at least 1.2-fold (0.09 log units) away from the limit.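

In this assay compound 3 returns a limit and not a number, so it has no exact place on the scale: the limit of > 100000 nM in this assay, at which 1 of the 3 values shown sits.

Hydroxymethyl in place of fluoro gives an at least 1.1-fold higher number from compound 2 to compound 3 (0.04 log units; that floor lies within the scatter), so only a floor can be read here and it does not separate the two compounds. Hydroxy in place of hydrogen on a saturated chain carbon bound to an aromatic carbon gives a number no lower from compound 1 to compound 3 (the limit leaves the size open), and the size of this step cannot be read. What this adds is a third kind of group on the same aromatic carbon: hydroxymethyl brings a hydrogen-bond donor and a hydrogen-bond acceptor that fluoro lacks, yet the number does not come down, so neither methyl, fluoro nor hydroxymethyl gives more than weak inhibition at this position.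

As far as these compounds go, it remains open whether an amine, a carboxylic acid or a longer chain on this aromatic carbon would give a clearly lower number than these three groups. From the compounds shown here alone, it also remains open how far the true value of compound 3 lies past the limit, and whether changing the 2-formylethenyl group would matter more than changing this position.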